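Taking the last chloro off compound 2

A few compounds are considered here, and "the series" means these few. Any claim that something is new, unique, unknown or untested is made for them only; others in the source may bear on it.

In a functional assay on DU-145 cells (Homo sapiens) for cytotoxicity, read by MTT assay, with a stated time of 68 h (on this read-out higher numbers stand for weaker inhibition and lower numbers for stronger inhibition), compound 1 (`O=C(/C=C/c1cccc(OCc2ccccc2)c1)c1ccc(Cl)cc1Cl`) gives 27300 nM and compound 2 (`O=C(/C=C/c1cccc(OCc2ccccc2)c1)c1ccc(Cl)cc1`) gives 43400 nM on a shared core. Going by the values given here, these are the only two numbers so far, and they lie within the scatter of each other, so compound 2 cannot be separated from compound 1 , its one neighbour on the scale.

Compound 3 (`O=C(/C=C/c1cccc(OCc2ccccc2)c1)c1ccccc1`) has not yet been measured. It differs from compound 2 by hydrogen in place of chloro on an aromatic carbon with hydrogen in place of chloro on an aromatic carbon, so that 4-chlorophenyl becomes phenyl.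

Among the compounds with values here, one measured step bears on this change, the same kind of replacement made at a different place. That step was a 1.6-fold higher number from compound 1 to compound 2 (0.20 log units; within the scatter) and it stands alone. A single step within the scatter sets no firm direction, although a slightly higher number would follow it. The step expected is a 1.2-fold higher number from compound 2 to compound 3 (0.06 log units; within the scatter) and it is estimated to stay within the scatter. Compound 3 is therefore estimated at 50000 nM with a range from 25000 nM to 100000 nM as its expected span.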

Compound 3, half-maximal inhibitory concentration: 42400 nM
The estimate for compound 3 lay 1.2-fold (0.07 log units) above the measured number, within the range that was stated.
By their numbers in this assay, from the lowest: compounds 1, 3 and 2 (each within the scatter of the next).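

In this assay, the hydrogen in place of the chloro on this aromatic carbon, para to a large group, gives a 1.0-fold lower number from compound 2 to compound 3 (0.01 log units; within the scatter), so this position shows no measurable response to the loss of the chloro. The earlier step removed only one of the two chloro groups, whereas phenyl in place of 2,4-dichlorophenyl removes both and gives a 1.6-fold higher number from compound 1 to compound 3 (0.19 log units; within the scatter), which shows that even the full change on this ring stays within the scatter and that all three compounds remain inseparable on this read-out. Nothing accompanying these numbers accounts for them.

From the compounds shown here alone, all three compounds carry only chloro or hydrogen on this ring, so it remains open whether a different group at this position, such as a methoxy, a nitrile or an amine, would move the number beyond the scatter. Also open, going by these compounds, is whether the same replacement would stay within the scatter if the rest of the shared core were changed, or in cells other than those of this assay.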